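The source may report more compounds than this note shows. Statements on the series, on what has been measured and on what is new or still open speak of the compounds shown alone.

In an in vitro functional assay on cells for agonist activity at Bombesin receptor subtype-3 (Mus musculus), read by luminescence and calcium flux (a lower number here means that less compound is needed, a higher number that more compound is needed for the effect), compound 3 `O=C(O)c1ccccc1-c1ccc(CCc2ncc(CC3CC3)[nH]2)cc1` gives 72 nM, the highest of the three numbers in hand. Compound 1 `O=C(O)c1ccccc1-c1ccc(CCc2ncc(CC3CCC3)[nH]2)cc1` gives 7.1 nM, and compound 2 `N#Cc1cccc(Cc2cnc(CCc3ccc(-c4ccccc4C(=O)O)cc3)[nH]2)c1` gives 20 nM. Compound 4 `CC(C)(C)c1cnc(CCc2ccc(-c3ccccc3C(=O)O)cc2)[nH]1` differs from compound 3 by tert-butyl in place of cyclopropylmethyl on an aromatic carbon. Going by the values given here, no measured step makes this same exchange; the nearest guide is the same position, where a 10-fold higher number from compound 1 to compound 3 (1.01 log units; beyond the scatter) and a 3.6-fold higher number from compound 2 to compound 3 (0.56 log units; beyond the scatter) show that it answers strongly to what sits there, and that the smallest group so far gave the highest number. As far as these compounds go, a branched group without a ring, placed directly on the ring carbon, is untested, so the direction is uncertain, and compound 4 is expected to give a number near 150 nM, within 30 nM to 700 nM, a step of a 2.1-fold higher number from compound 3 to compound 4 (0.32 log units; beyond the scatter) estimated from compound 3.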

Compound 4, half-maximal effective concentration: 2750 nM
Estimate against measurement, compound 4: 18-fold (1.26 log units) below, outside the stated range (above it).
By their numbers in this assay, from the lowest: compound 1; then compound 2; then compound 3; then compound 4.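

Cyclopropylmethyl and tert-butyl each hold 4 heavy atoms, yet in this assay the exchange brings a 38-fold higher number from compound 3 to compound 4 (1.58 log units; beyond the scatter) and so this position separates groups of equal atom count. Going by these compounds alone, the gap widens against the other groups, with a 140-fold higher number from compound 2 to compound 4 (2.14 log units; beyond the scatter) and a 390-fold higher number from compound 1 to compound 4 (2.59 log units; beyond the scatter) and all three steps exceed any among the earlier compounds. Each group with a ring gives a lower number than tert-butyl, which has none. As far as these compounds go, whether the missing ring or the missing chain carbon matters stays open, and an unbranched butyl chain or a cyclobutyl group set directly on the aromatic carbon would separate the two. Nothing given here explains the size of this step.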